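Furan-2-yl to 1H-imidazol-4-yl: cytotoxicity expected for compound 3

The compounds below may be only part of what the source reports. "The series", "measured", "known", "first", "only" and "open" are said of these compounds alone.

Compound 1 `OC[C@H]1O[C@@H](n2cc(F)c3c(-c4ccco4)ncnc32)[C@H](O)[C@@H]1O` — 310 nM
Compound 2 `OC[C@H]1O[C@@H](n2cc(F)c3c(-c4ccoc4)ncnc32)[C@H](O)[C@@H]1O` — 350 nM

In an ADME assay on BJ cells (Homo sapiens) for cytotoxicity, read by MTT assay, with a stated time of 72 h (a lower number here means that less compound is tolerated, a higher number that more compound is tolerated), compound 1 gives 310 nM, the lowest of the two numbers, while compound 2 gives 350 nM. Going by the values given here, the only measured step, a 1.1-fold higher number from compound 1 to compound 2 (0.05 log units; within the scatter), concerns furan-3-yl in place of furan-2-yl and lies within the scatter. Compound 3 `OC[C@H]1O[C@@H](n2cc(F)c3c(-c4c[nH]cn4)ncnc32)[C@H](O)[C@@H]1O` differs from compound 1 by 1H-imidazol-4-yl in place of furan-2-yl on an aromatic carbon. Among the compounds with values here, no measured step covers this change, so the expectation rests on the single within-scatter step alone: compound 3 is expected to show a step of a 1.1-fold higher number from compound 1 to compound 3 (0.05 log units; within the scatter), not beyond the scatter. Compound 3 is therefore estimated at 350 nM, with a range from 150 nM to 900 nM.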

Compound 3, half-maximal cytotoxic concentration: > 50000 nM
Compound 3 ended at the assay's limit; the forecaster's own chance of this, stated with the estimate: 10%; middle value at least 140-fold (2.15 log units) away from the limit.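

In this assay, the group on this aromatic carbon can shift the number far, which the swap between the two furans did not show: 1H-imidazol-4-yl in place of furan-2-yl gives an at least 160-fold higher number from compound 1 to compound 3 (2.20 log units; beyond the scatter), and in place of furan-3-yl it gives an at least 140-fold higher number from compound 2 to compound 3 (2.15 log units; beyond the scatter). The value of compound 3 is a limit, not a number: the limit of > 50000 nM in this assay, at which 1 of the 3 values shown sits.

The compounds shown do not separate the hydrogen-bond donor that enters from the second ring nitrogen. They also leave open where an amine or a carboxylic acid on this carbon would fall.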